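From thiophen-3-yl to 4-methylpiperidin-1-yl on the shared core

The source may report more compounds than this note shows. Statements on the series, on what has been measured and on what is new or still open speak of the compounds shown alone.

Of the compounds shown here, two sharing one core have been measured in an ADME assay (liver) for metabolic stability, with Liver microsome (Rattus norvegicus) as the target, using microsomes; a lower number here means slower removal, a higher number faster removal of the compound. Compound 1 `COc1ccc(-c2nn(-c3nc(C(=O)O)cs3)c3ccccc23)cc1` gives 618 mL/min/kg, and compound 2 `O=C(O)c1csc(-n2nc(-c3ccsc3)c3ccccc32)n1` gives 190 mL/min/kg, the lower of the two numbers. The next compound, compound 3 `CC1CCN(c2nn(-c3nc(C(=O)O)cs3)c3ccccc23)CC1`, keeps that core and changes one group: 4-methylpiperidin-1-yl in place of thiophen-3-yl on an aromatic carbon. For the measured compounds named here, only one measured step bears on this change, since it falls at the same place: a 3.3-fold lower number from compound 1 to compound 2 (0.51 log units; beyond the scatter), a modest step beyond the scatter, with thiophen-3-yl in place of 4-methoxyphenyl. It shows that the group at this place can move the number, but a single step between two aromatic groups says little about a non-aromatic ring. Going by the values given here, with compound 2 at 190 mL/min/kg, already the lower of only two numbers, a modest rise is expected rather than a further fall. The expected change is a 1.8-fold higher number from compound 2 to compound 3 (0.25 log units; within the scatter). The estimated clearance of compound 3 is 340 mL/min/kg, with an expected range from 120 mL/min/kg to 900 mL/min/kg.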

Compound 3, clearance: 260 mL/min/kg
Estimate against measurement, compound 3: 1.3-fold (0.12 log units) above; the measured number falls inside the stated range.
By their numbers in this assay, from the lowest: compounds 2 and 3 (each within the scatter of the next); then compound 1.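

In this assay the move from thiophen-3-yl to 4-methylpiperidin-1-yl gives a 1.4-fold higher number from compound 2 to compound 3 (0.14 log units; within the scatter) and so shows that a six-membered non-aromatic ring can take the place of a five-membered aromatic ring on this aromatic carbon with no change that can be told apart from repeat measurement. Set against the 4-methoxyphenyl group of the first compound, the same ring gives a 2.4-fold lower number from compound 1 to compound 3 (0.38 log units; beyond the scatter) and this places compound 3 with compound 2 on the lower side of compound 1, so among these three compounds a lower number at this position does not depend on the group being aromatic. Nothing available here explains why these groups give the numbers they do.

On these data alone, the effect of the methyl on the piperidine stays open, as does the effect of a morpholine or an open-chain amine at the same place. The carboxylic acid on the shared core is also the same in all three compounds, so what an amide there would do to the number cannot be judged from them.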